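A few compounds are considered here, and "the series" means these few. Any claim that something is new, unique, unknown or untested is made for them only; others in the source may bear on it.

Measured so far in a physicochemical assay for solubility, read by HPLC, in simulated intestinal fluid, with a stated time of 16 h, at pH 6.5; on this read-out lower numbers stand for lower solubility and higher numbers for higher solubility (compound, structure, value):
- compound 1 `CNC(=O)c1cc(C(=O)N[C@H]2CC[C@H](O)CC2)n([C@@H](C)c2ccc(Cl)cc2)n1` gives 102 ug/mL
- compound 2 `CC(=O)Nc1c(F)cc(C(=O)N[C@H]2CC[C@H](O)CC2)cc1O[C@@H](C)c1ccccc1` gives 996 ug/mL

Compound 1 holds the lower of the two numbers, and the gap up to compound 2 lies beyond the scatter. Compound 3 `CNC(=O)c1cc(C(=O)N[C@H]2CC[C@H](O)CC2)n([C@@H](C)c2ccccc2)n1` departs from compound 1 by one change, hydrogen in place of chloro on an aromatic carbon in which hydrogen stands in place of chloro on an aromatic carbon, para to a large group. Going by the values given here, no measured pair shows this change, so the expectation rests on little. A modest upward move in this assay is expected, with a 2.3-fold higher number from compound 1 to compound 3 (0.35 log units; beyond the scatter) as the estimated step and a return within the scatter still possible. For compound 3 the estimated value is 230 ug/mL with an expected range from 100 ug/mL to 550 ug/mL for the coming measurement.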

Compound 3, solubility: 366 ug/mL
The estimate for compound 3 lay 1.6-fold (0.20 log units) below the measured number; low and high end bracket the measured number.
By their numbers in this assay, from the lowest: compound 1; then compound 3; then compound 2.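

In this assay, going by these compounds alone, the change from 4-chlorophenyl to phenyl gives a 3.6-fold higher number from compound 1 to compound 3 (0.55 log units; beyond the scatter) and is the first single-place step. It shows that the read-out responds to what sits on this aromatic carbon, para to a large group, with hydrogen giving the higher number. No available measurement accounts for the size of this step.

On these data alone, whether a methoxy group, a nitrile or an amine on this carbon would give a number nearer to that of hydrogen or of chloro stays open. Also open, as far as these compounds go, is whether the step holds when other parts of the shared core change.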